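The compounds below may be only part of what the source reports. "The series", "measured", "known", "first", "only" and "open" are said of these compounds alone.

Of the compounds shown here, three of a shared core have been measured in an assay for inhibition of acyl-CoA:cholesterol acyltransferase (Oryctolagus cuniculus), using microsomes; on this read-out higher numbers stand for weaker inhibition and lower numbers for stronger inhibition. Compound 1 `CCCCCCCCCCC1(C(=O)Nc2c(C)ccc3c2OC(C)(C)C3)CCCC1` gives 240 nM there. Compound 2 `CCCCCCCCCCCCCCCC(=O)Nc1c(C)cc(C)c2c1OC(C)(C)C2` gives 26 nM in this assay. Compound 3 `CCCCCCCCCCCCC(C)(C)C(=O)Nc1c(C)cc(C)c2c1OC(C)(C)C2`, whose chain carries two methyl groups on the carbon next to the carbonyl, gives 33 nM in this assay.

Among the three numbers, compound 3 holds the second highest. Its nearest neighbour is compound 2, whose value lies within the scatter of compound 3, so nothing separates them. Compound 1 lies furthest away, its higher number standing beyond the scatter.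

Compound 4 `Cc1cc(C)c(NC(=O)C(C)(C)CCCCCCc2ccccc2)c2c1CC(C)(C)O2` has not yet been measured. Its difference from compound 3 is phenyl in place of hexyl on a saturated chain carbon, seven bonds along the chain from a carbonyl carbon. The chain is therefore shortened at its far end and closed by an aromatic ring in place of the saturated tail, while the core, the amide and the two methyl groups on the chain carbon next to the carbonyl stay as they are.

Among the compounds with values here, no measured pair in this set shows what such an exchange does in this assay, so the expectation rests on the spread of the three numbers alone. For compound 4 a step of a 1.5-fold higher number from compound 3 to compound 4 (0.18 log units; within the scatter) is expected, a change that would not clearly rise above the scatter. The value of compound 4 in this assay is estimated at 50 nM, with a range from 15 nM to 160 nM.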

Compound 4, half-maximal inhibitory concentration: 81 nM
The estimate for compound 4 lay 1.6-fold (0.21 log units) below the measured number, within the range that was stated.
By their numbers in this assay, from the lowest: compounds 2 and 3 (each within the scatter of the next); then compound 4; then compound 1.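

In this assay, within the data shown here, phenyl in place of hexyl on a saturated chain carbon, seven bonds along the chain from a carbonyl carbon, gives a 2.5-fold higher number from compound 3 to compound 4 (0.39 log units; beyond the scatter), the first step in this set that can be read, and a modest one. It shows that the far end of the chain is not indifferent to what stands there, since closing the chain with an aromatic ring weakens inhibition measurably, although compound 4 still reads 81 nM, so inhibition is reduced rather than lost. Nothing at hand accounts for the size of this step, so the result stands as an observation without an explanation.

The compounds shown leave open whether the change in the number follows from the aromatic ring itself or from the shorter chain that carries it, since a cyclohexyl at the same place or a longer chain ending in the same phenyl would be needed to tell these apart. They also leave open whether the same exchange would give a similar step on the unbranched chain of compound 2, and how a terminal amine or carboxylic acid at this position would read.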